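This account rests on a few compounds, and the source may have more. Where it says the series, first, only, none or still open, it means among the compounds named here.

Measured so far in an ADME assay on microsomes from liver (Homo sapiens) for metabolic stability; a lower number here means slower removal, a higher number faster removal of the compound:
- compound 1 `C[C@H](NC(=O)Cn1nnc2ccccc2c1=O)c1ccc(Br)cc1`: < 9.9 mL/min/kg (a limit of the assay)
- compound 2 `Cc1ccc([C@H](C)NC(=O)Cn2nnc3ccccc3c2=O)c(C)c1`: 33 mL/min/kg
- compound 3 `Cc1ccc([C@H](C)NC(=O)Cn2nnc3ccccc3c2=O)c(F)c1`: 28 mL/min/kg

Compound 3, at 28 mL/min/kg, cannot be separated from compound 2, since a 1.2-fold lower number from compound 2 to compound 3 (0.07 log units; within the scatter). Both numbers sit clearly apart from the limit reached by compound 1, as an at least 3.3-fold higher number from compound 1 to compound 2 (0.52 log units; beyond the scatter) and an at least 2.8-fold higher number from compound 1 to compound 3 (0.45 log units; beyond the scatter) show.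

Compound 4 `C[C@H](NC(=O)Cn1nnc2ccccc2c1=O)c1ccn(C)n1` carries 1-methyl-1H-pyrazol-3-yl in place of 2-fluoro-4-methylphenyl on a saturated chain carbon bound to an amide-type nitrogen and a saturated chain carbon. The two steps from compound 1 change the group at this same place, and both lie beyond the scatter, so the number in this assay does respond to this group. Neither step involves a pyrazolyl group, so they serve only as a rough guide to size. Since an at least 2.8-fold higher number from compound 1 to compound 3 (0.45 log units; beyond the scatter), compound 3 is not at the low end reached at this place, and a modest move to a lower number is expected. The expected step is a 1.8-fold lower number from compound 3 to compound 4 (0.24 log units; within the scatter). Compound 4 is estimated at 16 mL/min/kg, with an expected range of 9 mL/min/kg to 30 mL/min/kg.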

Compound 4, clearance: 12 mL/min/kg
For compound 4 the middle estimate is 1.3-fold (0.12 log units) above the measured one; measured number inside the range.
By their numbers in this assay, from the lowest: compound 4; then compounds 3 and 2 (each within the scatter of the next). At a limit, below all of these: compound 1.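

In this assay, 1-methyl-1H-pyrazol-3-yl, the only five-membered aromatic ring at this place among the compounds shown, gives a lower number than either of the two methyl-bearing phenyl groups, as a 2.3-fold lower number from compound 3 to compound 4 (0.37 log units; beyond the scatter) and a 2.8-fold lower number from compound 2 to compound 4 (0.44 log units; beyond the scatter) show. The number at this place can therefore drop clearly below those of compounds 2 and 3 without a 4-bromophenyl group, with a ring that has fewer heavy atoms and carries two nitrogens. The remaining step at this place is an at least 1.2-fold higher number from compound 1 to compound 4 (0.08 log units; that floor lies within the scatter), and this leaves that comparison open. Compound 1 gives only a limit: the limit of < 9.9 mL/min/kg in this assay, at which 1 of the 4 values shown sits.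

The change alters ring size, hetero atoms and heavy-atom count together, and the compounds shown do not separate these. Also open, as far as these compounds go, is how a pyridyl ring, or a pyrazole with a longer chain in place of its methyl, would read in this assay.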